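Exchanging benzylcarbamoyl for (thiophen-2-yl)sulfonyl

The compounds below may be only part of what the source reports. "The series", "measured", "known", "first", "only" and "open" are said of these compounds alone.

In a functional assay for inhibition, with Homo sapiens as the target (on this read-out higher numbers stand for weaker inhibition and lower numbers for stronger inhibition), compound 1 `CCCCNC(=O)N[C@@H](CNC(=O)c1ccc2c(c1)C(=O)N(CCC1CCNCC1)C2)C(=O)O` gives 16 nM and compound 2 `O=C(NCc1ccccc1)N[C@@H](CNC(=O)c1ccc2c(c1)C(=O)N(CCC1CCNCC1)C2)C(=O)O` gives 10 nM so compound 2 stands within the scatter of compound 1. For the measured compounds named here, compound 3 `O=C(NC[C@H](NS(=O)(=O)c1cccs1)C(=O)O)c1ccc2c(c1)C(=O)N(CCC1CCNCC1)C2` carries (thiophen-2-yl)sulfonyl in place of benzylcarbamoyl on an amine nitrogen and no measured step covers that exchange. Going by the values given here, the one measured step of a 1.6-fold lower number from compound 1 to compound 2 (0.20 log units; within the scatter) lies within the scatter and altered only the outer end of the leaving group, so it offers limited guidance. No shift beyond the scatter is therefore expected in this assay and the estimated step is a 1.2-fold higher number from compound 2 to compound 3 (0.08 log units; within the scatter) with wide uncertainty. The estimate for compound 3 is 12 nM with an expected range from 4 nM to 40 nM overall.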

Compound 3, half-maximal inhibitory concentration: 7 nM
Estimate against measurement, compound 3: 1.7-fold (0.23 log units) above; low and high end bracket the measured number.
By their numbers in this assay, from the lowest: compounds 3, 2 and 1 (each within the scatter of the next, the first and the last beyond it).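

In this assay the amine nitrogen accepts a sulfonyl group in place of a carbamoyl group: a 1.4-fold lower number from compound 2 to compound 3 (0.15 log units; within the scatter) comes with exchanging benzylcarbamoyl for (thiophen-2-yl)sulfonyl. Against butylcarbamoyl the same group gives a 2.3-fold lower number from compound 1 to compound 3 (0.36 log units; beyond the scatter) as the only step shown that clears the scatter, and only modestly. No available evidence bears on either step. Going by these compounds, whether the sulfonyl group or the thiophene ring carries this result stays open. A phenylsulfonyl or butylsulfonyl group on the same nitrogen would separate the two.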